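The compounds below may be only part of what the source reports. "The series", "measured", "known", "first", "only" and "open" are said of these compounds alone.

In a functional assay on SK-MEL-28 cells (Homo sapiens) for inhibition, read by sulforhodamine B assay, with a stated time of 48 h (on this read-out lower numbers stand for stronger inhibition of growth and higher numbers for weaker inhibition of growth), compound 1 `O=C(Cc1csc2nc(-c3ccc(Br)cc3)cn12)N/N=C/c1ccc(O)cc1` gives 60300 nM and compound 2 `COc1cccc(OC)c1/C=N/NC(=O)Cc1csc2nc(-c3ccc(Br)cc3)cn12` gives 41700 nM. These two numbers lie within the scatter of each other, so compound 2 stands level with compound 1 on the data so far. The next compound, compound 3 `O=C(Cc1csc2nc(-c3ccc(Br)cc3)cn12)N/N=C/c1ccc(Cl)cc1Cl`, keeps the shared core and carries 2,4-dichlorophenyl in place of 2,6-dimethoxyphenyl on a carbon with a double bond to nitrogen. Among the compounds with values here, only one measured step bears on this spot, the exchange of 4-hydroxyphenyl for 2,6-dimethoxyphenyl on that same carbon, and it came to a 1.4-fold lower number from compound 1 to compound 2 (0.16 log units; within the scatter). Within the data shown here, that is a single small step, and no measured compound carries chlorine on this group, so the data point in no direction. In this assay, no change beyond the scatter is expected, and the estimated step is a 1.2-fold lower number from compound 2 to compound 3 (0.08 log units; within the scatter). For compound 3 the estimated value is 35000 nM, with an expected range of 10000 nM to 90000 nM.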

Compound 3, concentration for 50% growth inhibition: < 100000 nM
Compound 3: no number, only a limit; the forecaster's own chance of this, stated with the estimate: 15%; the middle value does not contradict the limit.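

In this assay compound 3 gives < 100000 nM, which is a limit and not a number. The steps from compound 1 and from compound 2 to compound 3 cannot be read. The compounds shown leave open how 2,4-dichlorophenyl compares with the other two groups at this spot.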